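Varying the halogenated aryl amine on a shared core

This account rests on a few compounds, and the source may have more. Where it says the series, first, only, none or still open, it means among the compounds named here.

Compound 1, `O=C(CSc1nc(Nc2ccccc2)c2ccccc2n1)Nc1cccc([N+](=O)[O-])c1`, in a functional assay on PC-3 cells (Homo sapiens) for inhibition, read by MTT assay, with a stated time of 72 h (a higher number here means a weaker inhibitor, a lower number a stronger inhibitor), gives 11800 nM.
Compound 2, `C=CC(=O)Nc1cccc(NC(=O)CSc2nc(Nc3ccccc3Br)c3ccccc3n2)c1`, in this assay gives 17100 nM.

Of the compounds shown here, two have been measured in this assay so far. Compound 2 has the higher of the two numbers, but its nearest neighbour, compound 1, lies within the usual scatter of it, so the two cannot be told apart on these numbers. For the measured compounds named here, no step between compounds that differ in a single place has been measured, so there is no direct reference for how a change on the aryl amine moves the number.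

Compound 3, `C=CC(=O)Nc1cccc(NC(=O)CSc2nc(Nc3ccc(F)c(Cl)c3)c3ccccc3n2)c1`, has not yet been measured. It differs from compound 2 in one place: 3-chloro-4-fluorophenyl in place of 2-bromophenyl on a nitrogen on an aromatic ring. Going by the values given here, the two compounds measured so far give no guide to this kind of exchange, and there is no reason in the data to expect a step beyond the scatter in either direction. The step from compound 2 to compound 3 in this assay is therefore expected to be small, a 1.2-fold lower number from compound 2 to compound 3 (0.09 log units; within the scatter). Compound 3 in this assay is estimated at 14000 nM, with a range from 5000 nM to 40000 nM.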

Compound 3, half-maximal inhibitory concentration: > 50000 nM
Compound 3 ended at the assay's limit (the forecaster's own chance of this, stated with the estimate: 10%); middle value at least 3.5-fold (0.55 log units) away from the limit.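

In this assay, for the compounds shown here, 3-chloro-4-fluorophenyl in place of 2-bromophenyl on a nitrogen on an aromatic ring gives an at least 2.9-fold higher number from compound 2 to compound 3 (0.46 log units; beyond the scatter), the first step between compounds differing in one place, and it shows that the read-out at this position depends on which halogenated phenyl group is attached. Compound 3 gives > 50000 nM, which is a limit of the assay and not a number. The step is therefore a minimum and its full size cannot be read, so this exchange is known only to weaken inhibition by more than the usual scatter: the limit of > 50000 nM in this assay, at which 1 of the 3 values shown sits.

The exchange alters the halogens and where they sit on the phenyl ring together, so the compounds shown do not reveal which part of it carries the step, and compound 1 differs from both compounds in more than one place and gives no reference. A plain phenyl, 3-chlorophenyl or 4-fluorophenyl group on this nitrogen, with the rest of compound 2 kept, would be needed to separate these contributions.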